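A few compounds are considered here, and "the series" means these few. Any claim that something is new, unique, unknown or untested is made for them only; others in the source may bear on it.

Compound 1: `COc1cccc(C2=CCN(C(=O)[C@H]3NCC4(CC4)C[C@@H]3C(=O)NO)CC2)c1`, giving 40 nM in an assay on isolated protein for binding affinity to disintegrin and metalloproteinase domain-containing protein 10 (Homo sapiens); a lower number here means a stronger inhibitor, a higher number a weaker inhibitor.
Compound 2: `COC(=O)N1CC2(CC2)C[C@H](C(=O)NO)[C@H]1C(=O)N1CCC(c2ccccc2)CC1`, giving 19 nM in this assay.
Compound 3: `CC(C)c1cccc(N2CCN(C(=O)[C@H]3NCC4(CC4)C[C@@H]3C(=O)NO)CC2)c1`, giving 1100 nM in this assay.

Of the three numbers, compound 3 stands highest, which means it is the weakest inhibitor of the group: its value is well above that of compound 1 and further still above that of compound 2, and both gaps lie beyond the usual scatter of repeated measurements.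

Compound 4 is `O=C(NO)[C@H]1CC2(CC2)CN[C@@H]1C(=O)N1CCN(c2cccc(Cl)c2)CC1`. It differs from compound 3 in one place: chloro in place of isopropyl on an aromatic carbon, that is, 3-isopropylphenyl becomes 3-chlorophenyl. Within the data shown here, no measured pair shows this exact exchange, so the size of the step cannot be read off from the data. The other two compounds, which carry smaller or differently shaped groups on their outer ring, give much lower numbers than compound 3, so a lower number is expected for compound 4 as well, though the gain is uncertain. The step from compound 3 to compound 4 is estimated at a 3.1-fold lower number from compound 3 to compound 4 (0.50 log units; beyond the scatter) in this assay. For compound 4 the expected value is 350 nM, with a likely range from 90 nM to 1400 nM.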

Compound 4, half-maximal inhibitory concentration: 14 nM
Compound 4: middle estimate off by 25-fold (1.40 log units), on the high side; measured number below the stated range.
By their numbers in this assay, from the lowest: compounds 4 and 2 (each within the scatter of the next); then compound 1; then compound 3.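

The change of isopropyl to chloro on this aromatic carbon, meta to a large group, gives a 79-fold lower number from compound 3 to compound 4 (1.90 log units; beyond the scatter) in this assay. Among these compounds, this is the first pair here that differs in one place only, so it shows that the group on this carbon of the outer ring can by itself move the number by a large margin, with the rest of the molecule held constant. Nothing available here explains why a single chlorine atom in place of three carbons has so large an effect.

On these data alone, it remains open whether the gain comes from the presence of chloro or simply from the loss of isopropyl, a question that hydrogen, methyl or bromo on the same carbon would help settle. Also open, as far as these compounds go, is how chloro would fare on a different carbon of this ring.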